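The source may hold more compounds than are shown below. What is called first, only, known or untested is meant among the compounds shown, and "the series" means these compounds.

Compound 3, `O=C(O)c1cccc(CNc2cc(C(F)(F)F)cc3[nH]ncc23)c1`, stands in an assay for inhibition of Indoleamine 2,3-dioxygenase 1 (Homo sapiens), with stated times of 10 min and 60 min (on this read-out higher numbers stand for weaker inhibition and lower numbers for stronger inhibition), at > 100000 nM, which is a limit of the assay and not a number. Compound 1, `Nc1cccc(CNc2cc(C(F)(F)F)cc3[nH]ncc23)c1`, gives in this assay the limit > 100000 nM. Compound 2, `O=[N+]([O-])c1ccc2[nH]c(CNc3cc(C(F)(F)F)cc4[nH]ncc34)cc2c1`, gives in this assay the limit > 100000 nM. Among the measured compounds shown here, the single step within this set, a step that the two limits leave unreadable from compound 1 to compound 3, has no readable size because of the limit of > 100000 nM in this assay, at which 3 of the 3 values shown sit. Compound 4, `FC(F)(F)c1cccc(CNc2cc(C(F)(F)F)cc3[nH]ncc23)c1`, differs from compound 3 by trifluoromethyl in place of carboxy on an aromatic carbon. For the measured compounds named here, no measured step bears on this change with a readable size, so compound 4 is expected to stay at the limit, and the step that the limit leaves unreadable from compound 3 to compound 4 is expected to mean nothing beyond the scatter. The estimate for compound 4 in this assay is 150000 nM, expected to lie between 40000 nM and 600000 nM.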

Compound 4, half-maximal inhibitory concentration: > 100000 nM
Compound 4 was reported as a limit; the forecaster's own chance of this, stated with the estimate: 85%; the middle value does not contradict the limit.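

The steps from compound 3 to compound 4 and from compound 1 to compound 4 cannot be read, because each value is a limit: the limit of > 100000 nM in this assay, at which 4 of the 4 values shown sit. The compounds shown leave open whether any group at this place would give a readable value.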